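Compound 4: thiophen-2-yl for furan-2-yl in the ester

The source may report more compounds than this note shows. Statements on the series, on what has been measured and on what is new or still open speak of the compounds shown alone.

Measured compounds:
Compound 1, `O=C(OC1CCC(CN2CCN(c3cc(=O)c4cc(C(F)(F)F)cc([N+](=O)[O-])c4s3)CC2)CC1)c1ccco1`: in an ADME assay on cells (Hepatocyte, Mus musculus) for metabolic stability (a lower number here means that the compound disappears faster, a higher number that the compound lasts longer), compound 1 gives < 0.075 h, which is a limit of the assay.
Compound 2, `CS(=O)(=O)NC1CCC(CN2CCN(c3cc(=O)c4cc(C(F)(F)F)cc([N+](=O)[O-])c4s3)CC2)CC1`: in this assay compound 2 gives > 1.55 h, a limit of the assay.
Compound 3, `CC(=O)NC1CCC(CN2CCN(c3cc(=O)c4cc(C(F)(F)F)cc([N+](=O)[O-])c4s3)CC2)CC1`: in this assay compound 3 gives > 1.55 h, again a limit of the assay.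

Compound 1 is known only through (the limit of < 0.075 h in this assay, at which 1 of the 3 values shown sits); compounds 2 and 3 sit at the limit of > 1.55 h in this assay, at which 2 of the 3 values shown sit. The steps of an at least 20-fold higher number from compound 1 to compound 2 (1.31 log units; beyond the scatter) and an at least 20-fold higher number from compound 1 to compound 3 (1.31 log units; beyond the scatter) are both large; the step that the two limits leave unreadable from compound 2 to compound 3 cannot be read because both ends are limits.

Compound 4 is `O=C(OC1CCC(CN2CCN(c3cc(=O)c4cc(C(F)(F)F)cc([N+](=O)[O-])c4s3)CC2)CC1)c1cccs1`. Its difference from compound 1 is thiophen-2-yl in place of furan-2-yl on a carbonyl carbon. Both measured steps away from compound 1 remove the whole ((furan-2-yl)carbonyl)oxy group and replace it with an amide, so neither covers a change that keeps the ester and exchanges only the aromatic ring on its carbonyl carbon. For the measured compounds named here, nothing among the measured compounds therefore points to a step beyond the scatter, and compound 4 is expected to stand close to compound 1, with a step that the limit leaves unreadable from compound 1 to compound 4 taken as no step beyond the scatter. Compound 4 is estimated at 0.06 h, within 0.03 h to 0.15 h, most likely reported again as a limit.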

Compound 4, half-life: 0.0867 h
Beside the measured number, compound 4's estimate is 1.4-fold (0.16 log units) below it, and the stated range covers the measured number.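

In this assay compound 4 gives 0.0867 h, so this ester has a readable number, and it stays far from both amides, with an at least 17-fold lower number from compound 3 to compound 4 (1.25 log units; beyond the scatter) and an at least 17-fold lower number from compound 2 to compound 4 (1.25 log units; beyond the scatter). Compound 1 is a limit of the assay at < 0.075 h. For the compounds shown here, the ring exchange on the carbonyl carbon reads as an at least 1.1-fold higher number from compound 1 to compound 4 (0.06 log units; that floor lies within the scatter), which shows no change beyond the scatter while leaving its true size open, and across the four compounds the short half-life goes with the ester, with either furan-2-yl or thiophen-2-yl, against the longer-lasting amides, with no compound going against this.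

Going by these compounds, it remains open whether the ester link itself or the five-membered aromatic ring on it goes with the short half-life; an amide bearing thiophen-2-yl on its carbonyl carbon, in place of the ester, would separate the two. Also open, on these data alone, are how a phenyl ring or a plain methyl on the ester carbonyl carbon would read, and how long the two amides actually last.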